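The source may hold more compounds than are shown below. What is called first, only, known or untested is meant among the compounds shown, and "the series" means these compounds.

Working notes on the series. Of the compounds shown here, three have numbers so far. In a functional assay for inhibition, with Homo sapiens as the target (a higher number here means a weaker inhibitor, a lower number a stronger inhibitor), compound 1 `c1coc(-c2ccnc(Nc3ccc(-n4ccnc4)cc3)n2)c1` gives 2200 nM, compound 2 `NS(=O)(=O)c1ccc(Nc2nccc(-c3cccnc3)n2)cc1` gives 200 nM and compound 3 `c1ccc(-c2ccnc(Nc3ccc(-n4ccnc4)cc3)n2)nc1` gives 1400 nM. Among the compounds with values here, compound 3 stands second highest of the three numbers; its nearest neighbour is compound 1, and the one measured single-point step, a 1.6-fold lower number from compound 1 to compound 3 (0.20 log units; within the scatter), lies within the scatter. Within the data shown here, compound 2 gives the lowest number, beyond the scatter from compound 3, but no single-point step joins these two compounds, so that pair shows only its two values.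

Compound 4 `CCc1ccc(Nc2nccc(-c3ccccn3)n2)cc1` differs from compound 3 by ethyl in place of 1H-imidazol-1-yl on an aromatic carbon. Among the measured compounds shown here, no measured step bears on this change: the only step known is pyridin-2-yl in place of furan-2-yl on an aromatic carbon, a different group at a different place, and compound 2 differs from compound 3 in more than one place. For the measured compounds named here, with no step of the same kind to lean on, the expectation is a move no larger than the scatter, or a modest shift toward a higher number, giving an expected step of a 1.8-fold higher number from compound 3 to compound 4 (0.25 log units; within the scatter). Compound 4 is therefore estimated at 2500 nM, with a range from 800 nM to 8000 nM.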

Compound 4, half-maximal inhibitory concentration: 2100 nM
Compound 4: the middle estimate sits 1.2-fold (0.08 log units) above what was measured; the range from low to high includes it.
By their numbers in this assay, from the lowest: compound 2; then compounds 3, 4 and 1 (each within the scatter of the next).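

In this assay, within the data shown here, the exchange at this place, on an aromatic carbon of a six-membered aromatic ring of carbon only and para to a large group, gives a 1.5-fold higher number from compound 3 to compound 4 (0.18 log units; within the scatter) and is the first measured step at this position. The group that leaves has 5 heavy atoms, a five-membered aromatic ring and 2 hydrogen-bond acceptors, while ethyl has 2 heavy atoms, no ring and 0 hydrogen-bond acceptors, yet the two compounds remain within the scatter of each other, so this pair gives no sign that the imidazolyl ring matters to the read-out. No measurement at hand offers an explanation for this result.

Compound 3 and compound 4 each differ in more than one place from compound 2, which gives 200 nM and so its lower number cannot be assigned to any single group. Also open, as far as these compounds go, is how a primary amine, a carboxylic acid or a longer alkyl chain at this place would stand in this assay relative to ethyl.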